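One Amine Exchanged on a Shared Core

The source may hold more compounds than are shown below. What is called first, only, known or untested is meant among the compounds shown, and "the series" means these compounds.

Two compounds have been measured so far in an in vitro assay on 293-EBNA cells for binding affinity to corticotropin-releasing factor receptor 1 (Homo sapiens); a lower number here means a stronger inhibitor, a higher number a weaker inhibitor:

Compound 1, `CCCCN(CC)c1nc(C)nc2c1nnn2-c1c(Cl)cc(OC)cc1OC`, gives 4.4 nM.
Compound 2, `CCN(CC)c1nc(C)nc2c1ncn2-c1ccc(C(C)C)cc1Br`, gives 12.4 nM.

Compound 2 thus has the higher of the two numbers, meaning the weaker binding; compound 1 stands at a lower number, and the gap between them lies beyond the usual scatter of repeated measurements. The two compounds differ from each other in several places at once, so no single structural change can be read out of that gap.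

Compound 3, `CCCC(CC)Nc1nc(C)nc2c1ncn2-c1ccc(C(C)C)cc1Br`, keeps everything of compound 2 apart from one group: (1-ethylbutyl)amino in place of diethylamino on an aromatic carbon. The new group sits on the shared core next to the ring nitrogen and ortho to a fused ring.

Among the compounds with values here, no measured pair shows this exchange on its own, so the expected step in this assay cannot be taken from a comparison. It is estimated as a small step, most likely within the scatter, with a slight lean toward a lower number. Compound 3 is therefore expected to give about 7 nM, in a range from 1.5 nM to 30 nM, which means an expected step of a 1.8-fold lower number from compound 2 to compound 3 (0.25 log units; within the scatter).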

Compound 3, inhibition constant: 4.4 nM
The estimate for compound 3 lay 1.6-fold (0.20 log units) above the measured number; measured number inside the range.
By their numbers in this assay, from the lowest: compounds 1 and 3 (each within the scatter of the next); then compound 2.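

In this assay, within the data shown here, the exchange of diethylamino for (1-ethylbutyl)amino is the first change that can be read on its own, and it gives a 2.8-fold lower number from compound 2 to compound 3 (0.45 log units; beyond the scatter). This shows that the group on this aromatic carbon of the shared core, next to the ring nitrogen and ortho to a fused ring, can shift the binding number, and that here the change goes toward stronger binding. The entering group differs from the leaving one in two counted ways at once, with 7 heavy atoms instead of 5 and 1 hydrogen-bond donor instead of 0, so the step cannot be assigned to either difference, and no supporting measurement is available to explain it.

Still open, going by these compounds, is whether the step follows the extra carbon atoms or the amine hydrogen, a question on which dipropylamino, an amine with longer chains and no such hydrogen, would bear. Also open, on these data alone, is whether the same exchange would give a similar step on the core of compound 1, which carries a different amine and a different aromatic ring.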